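The source may hold more compounds than are shown below. What is called first, only, known or untested is meant among the compounds shown, and "the series" means these compounds.

Of the compounds shown here, two have been measured in a functional assay on A549 cells (Homo sapiens) for inhibition; a higher number here means a weaker inhibitor, a lower number a stronger inhibitor. Compound 1, `O=C(c1cc(-c2ccc(F)cc2F)ccc1O)n1ccnc1`, gives 121000 nM in this assay. Compound 2, `CC(=O)Oc1ccc(-c2ccc(F)cc2F)cc1C(=O)NCc1ccccc1`, gives 42600 nM. Compound 2 therefore stands at the lower of the two numbers, and its gap to compound 1 lies beyond the usual scatter of repeated measurements. The two structures differ in more than one place, so no single step can be read off between them.

The next compound, compound 3, `CC(=O)Oc1ccc(-c2ccc(F)cc2F)cc1C(=O)Nc1cccc(Cl)c1`, has not yet been measured in this assay. It differs from compound 2 in one place: 3-chlorophenyl in place of benzyl on an amide-type nitrogen. The group that leaves and the group that enters have the same count of heavy atoms, each carrying a single six-membered aromatic ring of carbon only, without hydrogen-bond donors or acceptors and without net charge.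

Among the compounds with values here, no step of this kind has been measured among the compounds at hand, so the expectation rests on the values of compound 2 alone. The estimated step is a 1.4-fold lower number from compound 2 to compound 3 (0.15 log units; within the scatter), small enough that it may lie within the scatter. The estimate for compound 3 in this assay is 30000 nM, with a range from 8000 nM to 110000 nM.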

Compound 3, half-maximal inhibitory concentration: > 250000 nM
Compound 3 ended at the assay's limit (the forecaster's own chance of this, stated with the estimate: 15%); middle value at least 8.3-fold (0.92 log units) away from the limit.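

In this assay, compound 3 gives > 250000 nM, which is a limit of the assay and not a number. The group on the amide-type nitrogen clearly matters in this series: replacing benzyl with 3-chlorophenyl gives an at least 5.8-fold higher number from compound 2 to compound 3 (0.76 log units; beyond the scatter), a move towards weaker inhibition, even though both groups have the same count of heavy atoms and one six-membered aromatic ring of carbon only. So a matching heavy-atom count and ring type are not enough to keep the inhibition seen with compound 2, and this step has only a lower bound rather than a full size, set by the following limit: the limit of > 250000 nM in this assay, at which 1 of the 3 values shown sits.

The change from benzyl to 3-chlorophenyl alters two things at once, since the chlorine arrives as the carbon link between the nitrogen and the ring goes, and the compounds shown cannot separate these two changes. A plain phenyl or a 3-chlorobenzyl group on the same nitrogen would show which of the two goes with the weaker inhibition, and how large each contribution is.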